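The source may report more compounds than this note shows. Statements on the series, on what has been measured and on what is new or still open speak of the compounds shown alone.

Compound 1, with the structure `COc1ccccc1N1CCN(CCCNc2ncccc2C(=O)N(C)C)CC1`, is the starting point. In a functional assay on aorta for antagonist activity at Alpha-1D adrenergic receptor (Rattus norvegicus) (on this read-out lower numbers stand for tighter binding and higher numbers for weaker binding), compound 1 gives 20 nM. Two close relatives have been measured alongside it. Compound 3, `COc1ccccc1N1CCN(CCCNc2ncc(C#N)cc2C(=O)N(C)C)CC1`, gives 20 nM, and the step of no change at the digits printed from compound 1 to compound 3 (within the scatter) shows the two standing level, together the highest numbers of the three. Compound 2, `COc1ccccc1N1CCN(CCCNc2ncccc2C(=O)C2CC2)CC1`, gives 2 nM, so the step of a 10-fold lower number from compound 1 to compound 2 (1.00 log units; beyond the scatter) is the only clear movement in the set.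

The new compound is compound 4, `CN(C)C(=O)c1cccnc1NCCCN1CCN(c2ccccc2-c2ncco2)CC1`. Its difference from compound 1 is 1,3-oxazol-2-yl in place of methoxy on an aromatic carbon. Neither measured step bears directly on this change: one replaced dimethylamino with cyclopropyl on a carbonyl carbon, the other added cyano on an aromatic carbon, and both left the methoxy untouched. The set therefore gives no anchor for swapping the methoxy for 1,3-oxazol-2-yl, and no step beyond the scatter is asserted with confidence.

Given that, compound 4 is expected to land near compound 1, with the step of a 1.3-fold higher number from compound 1 to compound 4 (0.10 log units; within the scatter) estimated as small. The estimate for compound 4 in this assay is 25 nM, within a range from 6 nM to 100 nM.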

Compound 4, dissociation constant: 25.1 nM
Estimate against measurement, compound 4: 1.0-fold (0.00 log units) below; the measured number falls inside the stated range.
By their numbers in this assay, from the lowest: compound 2; then compounds 1, 3 and 4 (each within the scatter of the next).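

Within the data shown here, until this result, the methoxy on the aromatic carbon had stayed the same in every compound, so nothing showed whether this place would tolerate a change. In this assay, the swap to 1,3-oxazol-2-yl gives a 1.3-fold higher number from compound 1 to compound 4 (0.10 log units; within the scatter), so a group of 5 heavy atoms carrying a five-membered aromatic ring can replace one of 2 heavy atoms with no ring, ortho to a large group, without moving the read-out beyond the usual scatter. Nothing measured here explains why the number stays level, and this one swap cannot separate the many ways in which the two groups differ.

The compounds shown leave open whether a much smaller group such as fluorine, a hydroxyl or a longer chain such as an ethoxy would also leave the number level at this place, so the limits of what it accepts remain unknown. They also leave open whether the change on the carbonyl carbon, which gave a 10-fold lower number from compound 1 to compound 2 (1.00 log units; beyond the scatter), would give a similar drop when combined with 1,3-oxazol-2-yl.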